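Shifting the formyl group from compound 3 to compound 4

This account rests on a few compounds, and the source may have more. Where it says the series, first, only, none or still open, it means among the compounds named here.

Values in a functional assay on COLO 205 cells (Homo sapiens) for inhibition, read by MTT assay, with a stated time of 48 h; a lower number here means a stronger inhibitor, a higher number a weaker inhibitor:
- Compound 1 `COc1cc(C(=O)/C=C/c2ccc(F)cc2)cc(OC)c1OC`: 25700 nM
- Compound 2 `COc1cc(C(=O)/C=C/c2ccccc2C=O)cc(OC)c1OC`: 88000 nM
- Compound 3 `COc1cc(C(=O)/C=C/c2cccc(C=O)c2)cc(OC)c1OC`: 22500 nM

Compound 3 sits level with its nearest neighbour, a 1.1-fold lower number from compound 1 to compound 3 (0.06 log units; within the scatter). Its furthest neighbour lies clearly apart, a 3.9-fold lower number from compound 2 to compound 3 (0.59 log units; beyond the scatter).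

Compound 4 `COc1cc(C(=O)/C=C/c2ccc(C=O)cc2)cc(OC)c1OC` remains unmeasured. The change is 4-formylphenyl in place of 3-formylphenyl on a double-bonded chain carbon bound to a double-bonded chain carbon.

For the measured compounds named here, two steps bear on it. Formyl placement has mattered once, a 3.9-fold lower number from compound 2 to compound 3 (0.59 log units; beyond the scatter), while the closest precedent, the 4-fluorophenyl of compound 1, shows no separation, a 1.1-fold lower number from compound 1 to compound 3 (0.06 log units; within the scatter). No step beyond the scatter is therefore expected in this assay, and the estimated step is a 1.1-fold higher number from compound 3 to compound 4 (0.05 log units; within the scatter). The estimate for compound 4 is 25000 nM, with an expected range of 10000 nM to 60000 nM.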

Compound 4, half-maximal inhibitory concentration: 68800 nM
Compound 4: middle estimate off by 2.8-fold (0.44 log units), on the low side, and the stated range ends below it.
By their numbers in this assay, from the lowest: compounds 3 and 1 (each within the scatter of the next); then compounds 4 and 2 (each within the scatter of the next).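

In this assay, the 4-formylphenyl separates from the 3-formylphenyl (a 3.1-fold higher number from compound 3 to compound 4 (0.49 log units; beyond the scatter)) but not from the 2-formylphenyl (a 1.3-fold lower number from compound 2 to compound 4 (0.11 log units; within the scatter)), so compound 3 alone stands apart among the formyl isomers. Formyl in place of fluoro on an aromatic carbon also gives a step beyond the scatter (a 2.7-fold higher number from compound 1 to compound 4 (0.43 log units; beyond the scatter)), so the 4-fluorophenyl of compound 1 is no stand-in for the 4-formylphenyl. No measurement at hand accounts for these steps.

Open: whether a carboxylic acid or an amine in place of formyl on an aromatic carbon would match compound 3 or compound 4.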